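The compounds below may be only part of what the source reports. "The series", "measured", "known", "first", "only" and "open" are said of these compounds alone.

Measured compounds in an assay on isolated protein for inhibition of Long-chain-fatty-acid--CoA ligase 1 (Mus musculus), read by mass spectrometry, with a stated time of 90 min, in the presence of a further agent that is not named here; on this read-out lower numbers stand for stronger inhibition and higher numbers for weaker inhibition:
compound 1 `Cc1cccc(Cc2nc3cc(O[C@H]4CC[C@@H](C(=O)O)CC4)ccc3n2C)c1`, 30 nM
compound 2 `Cc1cccc(Cc2nc3cc(O[C@H]4CC[C@@H](C(N)=O)CC4)ccc3n2C)c1`, 190 nM
compound 3 `Cc1cccc(Cc2nc3cc(O[C@H]4CC[C@@H](c5nnn[nH]5)CC4)ccc3n2C)c1`, 25 nM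

Compound 3 stands lowest of the three numbers, but its gap to compound 1 is within the scatter (a 1.2-fold lower number from compound 1 to compound 3 (0.08 log units; within the scatter)); only compound 2 sits apart, with a 7.6-fold lower number from compound 2 to compound 3 (0.88 log units; beyond the scatter) and a 6.3-fold higher number from compound 1 to compound 2 (0.80 log units; beyond the scatter). Compound 4 `Cc1cccc(Cc2nc3cc(O[C@H]4CC[C@@H](c5noc(=O)[nH]5)CC4)ccc3n2C)c1` is not yet measured; it differs from compound 3 by a group of 6 heavy atoms (2 carbon, 2 nitrogen, 2 oxygen; one five-membered aromatic ring with 3 hetero atoms) in place of a group of 5 heavy atoms (1 carbon, 4 nitrogen; one five-membered aromatic ring with 4 hetero atoms), on a saturated ring carbon. For the measured compounds named here, the steps that bear on this are the two earlier exchanges at the same ring carbon: carboxy to 1H-tetrazol-5-yl left the number where it was, carbamoyl to 1H-tetrazol-5-yl moved it. The present exchange resembles the first, so the expected step is a 1.6-fold higher number from compound 3 to compound 4 (0.20 log units; within the scatter), not beyond the scatter. Compound 4 is estimated at 40 nM, in the range 15 nM to 120 nM.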

Compound 4, half-maximal inhibitory concentration: 100 nM
The estimate for compound 4 lay 2.5-fold (0.40 log units) below the measured number; the measured number falls inside the stated range.
By their numbers in this assay, from the lowest: compounds 3 and 1 (each within the scatter of the next); then compounds 4 and 2 (each within the scatter of the next).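

In this assay, the saturated ring carbon does not treat every five-membered aromatic ring alike: a 4.0-fold higher number from compound 3 to compound 4 (0.60 log units; beyond the scatter), so the match between carboxy and 1H-tetrazol-5-yl does not extend to the entering ring. That ring also falls behind carboxy, with a 3.3-fold higher number from compound 1 to compound 4 (0.52 log units; beyond the scatter), while it cannot be separated from carbamoyl, with a 1.9-fold lower number from compound 2 to compound 4 (0.28 log units; within the scatter). No measurement available here accounts for the gap between the two rings. Open, as far as these compounds go, is whether a sulfonic acid or an acyl sulfonamide on this ring carbon would group with compound 1 and compound 3 or with compound 2 and compound 4.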